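The compounds below may be only part of what the source reports. "The series", "measured", "known", "first", "only" and "open" are said of these compounds alone.

Measured so far in a physicochemical assay for lipophilicity; a lower number here means a more polar compound, a higher number a more lipophilic compound:
compound 1 `CC(/C=C/CC(C)CCCC(C)C)=C\C(=O)OC(C)(C)C` gives 7.56;
compound 2 `COC(C)(C)CCCC(C)C/C=C/C(C)=C/C(=O)OC(C)(C)C` gives 6.36;
compound 3 `CCOC(=O)/C=C(C)/C=C/CC(C)CCCC(C)CC` gives 7.81.

Among these three, compound 2 has the lowest number, with compound 1 the nearest to it and compound 3 the furthest, both beyond the scatter. The only step measured between two of these compounds is the one a number 1.20 log units lower from compound 1 to compound 2 (beyond the scatter), which concerns a methoxy group on the chain and not the ester end of the molecule.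

Compound 4 `COC(C)(C)CCCC(C)C/C=C/C(C)=C/C(N)=O` differs from compound 2 at that ester end: amino in place of tert-butoxy on a carbonyl carbon. Among the compounds with values here, no measured step covers this kind of exchange, so the expectation rests on the general behaviour of a tert-butoxycarbonyl turning into a carbamoyl, which carries one hydrogen-bond donor in place of one hydrogen-bond acceptor and four fewer carbon atoms. A large drop in this assay, clearly beyond the scatter and larger than the step from compound 1 to compound 2, is expected, namely a number 2.96 log units lower from compound 2 to compound 4 (beyond the scatter). Compound 4 is therefore estimated at 3.4, with a range from 2.6 to 4.2.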

Compound 4, partition coefficient: 3.52
The estimate for compound 4 lay 0.12 log units below the measured number; the measured number falls inside the stated range.
By their numbers in this assay, from the lowest: compound 4; then compound 2; then compounds 1 and 3 (each within the scatter of the next).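

In this assay, the ester end of the molecule now has a measured step of its own, and amino in place of tert-butoxy on a carbonyl carbon gives a large change (a number 2.84 log units lower from compound 2 to compound 4 (beyond the scatter)). This step is larger than the only earlier one, which was made on the chain (a number 1.20 log units lower from compound 1 to compound 2 (beyond the scatter)), so in these compounds the exchange at the carbonyl carbon moves the number further than the methoxy group did. Nothing measured here accounts for the size of this step.

Going by these compounds, whether another group on the carbonyl carbon, such as methylamino or hydroxy as in a carboxylic acid, would land nearer compound 2 or compound 4 remains open. On these data alone, it is also open whether the same exchange gives a similar step on compound 1, which lacks the chain methoxy group.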